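The source may report more compounds than this note shows. Statements on the series, on what has been measured and on what is new or still open speak of the compounds shown alone.

Compound 1 `Cc1nc(N2CCCCC2)c2nnn(-c3ccc(C(C)C)cc3Br)c2n1` gives 46 nM in an in vitro assay on 293-EBNA cells for binding affinity to corticotropin-releasing factor receptor 1 (Homo sapiens); a higher number here means a weaker inhibitor, a lower number a stronger inhibitor. Compound 2 `CCCCN(CC)c1nc(C)nc2c1nnn2-c1c(C)cc(C)cc1C` gives 27.5 nM in this assay. Compound 3 `CCC(COC)Nc1nc(C)nc2c1nnn2-c1c(C)cc(C)cc1C` gives 59.4 nM in this assay.

Compound 2 holds the lowest of the three numbers; compound 1 lies within the scatter of it, while compound 3 stands beyond it. The unmeasured compound 4 `CCC(CC)Nc1nc(C)nc2c1nnn2-c1c(C)cc(C)cc1C` differs from compound 2 by (pentan-3-yl)amino in place of butyl(ethyl)amino on an aromatic carbon. Within the data shown here, only one measured step touches this position: a 2.2-fold higher number from compound 2 to compound 3 (0.33 log units; beyond the scatter), in which the (1-(methoxymethyl)propyl)amino group replaced the same butyl(ethyl)amino. Compound 4 and compound 3 differ only in that side chain, so that step is a loose guide at best. One expects a small step, a 1.5-fold higher number from compound 2 to compound 4 (0.16 log units; within the scatter), likely within the scatter. Compound 4 is therefore estimated at 40 nM, with a range from 15 nM to 110 nM.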

Compound 4, inhibition constant: 5.7 nM
Compound 4: the middle estimate sits 7.0-fold (0.85 log units) above what was measured; the whole stated range lies above it.
By their numbers in this assay, from the lowest: compound 4; then compounds 2, 1 and 3 (each within the scatter of the next, the first and the last beyond it).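

Putting (pentan-3-yl)amino in place of butyl(ethyl)amino on this aromatic carbon brings a 4.8-fold lower number from compound 2 to compound 4 (0.68 log units; beyond the scatter), the opposite direction to a 2.2-fold higher number from compound 2 to compound 3 (0.33 log units; beyond the scatter), so replacing butyl(ethyl)amino does not in itself raise the number. Methyl in place of methoxy on the chain brings a 10-fold lower number from compound 3 to compound 4 (1.02 log units; beyond the scatter), which ties the higher number of compound 3 to that methoxy and shows how sensitive this side chain is to a single change.

From the compounds shown here alone, whether a cyclopentylamino group or a longer branched chain would lower the number further remains open, as does whether (pentan-3-yl)amino would act alike on the core of compound 1. Nothing available explains why these side chains differ so much.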